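From Ethyl to a Sulfur-Bearing Group on One Ring Carbon

The source may hold more compounds than are shown below. What is called first, only, known or untested is meant among the compounds shown, and "the series" means these compounds.

Measured compounds:
compound 1 `Cc1nc2cc(Cl)c(Cl)cc2n1C1CCCC1`: 40000 nM
compound 2 `CCc1nc2cc(Cl)c(Cl)cc2n1C1CCCC1`: 52000 nM

Only these two compounds have been measured in a functional assay on MCF7 cells (Homo sapiens) for cytotoxicity, read by MTT assay, with a stated time of 48 h; on this read-out lower numbers stand for stronger inhibition of growth and higher numbers for weaker inhibition of growth. There, compound 2 gives 52000 nM, a value within the scatter of compound 1.

Compound 3 `C[S+]([O-])c1nc2cc(Cl)c(Cl)cc2n1C1CCCC1` has not yet been measured. It keeps the shared core and the cyclopentyl group of compound 2 and differs in one place: a group of 3 heavy atoms (1 carbon, 1 oxygen, 1 sulfur; no ring) in place of a group of 2 heavy atoms (2 carbon; no ring), on an aromatic carbon. The new group stands on an aromatic carbon of a five-membered aromatic ring with 2 nitrogen, between two ring nitrogen atoms.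

Within the data shown here, one measured step bears on this change: a 1.3-fold higher number from compound 1 to compound 2 (0.11 log units; within the scatter). That step placed methyl in place of hydrogen on a saturated chain carbon bound to an aromatic carbon, so it involved carbon alone. Among the measured compounds shown here, no measured compound carries sulfur or oxygen in this place, which leaves the guidance thin. No step beyond the scatter is therefore expected in this assay, and no direction can be firmly expected. The expected change is a 1.2-fold lower number from compound 2 to compound 3 (0.06 log units; within the scatter). Compound 3 is estimated at 45000 nM, with an expected range of 15000 nM to 110000 nM.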

Compound 3, concentration for 50% growth inhibition: 500 nM
Compound 3: the middle estimate sits 90-fold (1.95 log units) above what was measured, outside the stated range (below it).
By their numbers in this assay, from the lowest: compound 3; then compounds 1 and 2 (each within the scatter of the next).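

In this assay, the aromatic carbon between two ring nitrogen atoms turns out to be far from indifferent: methyl and ethyl had left the number in the same range, yet the group of 3 heavy atoms (1 carbon, 1 oxygen, 1 sulfur) gives a 100-fold lower number from compound 2 to compound 3 (2.02 log units; beyond the scatter) in place of ethyl, and an 80-fold lower number from compound 1 to compound 3 (1.90 log units; beyond the scatter) in place of one carbon atom. This carbon can therefore carry a change that moves growth inhibition strongly, which a step involving carbon alone had not revealed. No measurement shown here accounts for the size of this step.

The entering group differs from ethyl in several ways at once, with sulfur and oxygen present and a count of 1 hydrogen-bond acceptor against 0, and these three compounds cannot separate those differences from one another. From the compounds shown here alone, how a methylthio group, a methylsulfonyl group or an amine would read on this same carbon stays open, as does whether the large step would persist if the cyclopentyl group gave way to a longer chain.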